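Dioxopyrrolidinyl in place of the larger side group

The compounds below may be only part of what the source reports. "The series", "measured", "known", "first", "only" and "open" are said of these compounds alone.

Measured so far:
compound 1 `CCCCNC(=S)NC1=C(C#N)C(c2ccc(Cl)cc2Cl)C2=C(CCCC2=O)N1c1ccc(S(N)(=O)=O)cc1`: 35%
compound 2 `N#CC1=C(NC(=S)Nc2ccc(Cl)cc2)N(c2ccc(S(N)(=O)=O)cc2)C2=C(C(=O)CCC2)C1c1ccc(Cl)cc1Cl`: 100%

In a functional assay on Ehrlich cells (Mus musculus) for cytotoxicity, read by trypan blue exclusion, with a stated time of 2 h, tested at 50 ug/mL (on this read-out higher numbers stand for a stronger effect at the one concentration tested and lower numbers for a weaker effect), compound 1 gives 35% and compound 2 gives 100%, the highest of the two numbers; its nearest neighbour is compound 1, separated by a number 65 percentage points higher from compound 1 to compound 2 (beyond the scatter). Compound 3 `N#CC1=C(N2C(=O)CCC2=O)N(c2ccc(S(N)(=O)=O)cc2)C2=C(C(=O)CCC2)C1c1ccc(Cl)cc1Cl` differs from compound 2 by a group of 7 heavy atoms (4 carbon, 1 nitrogen, 2 oxygen; one five-membered non-aromatic ring with 1 hetero atom) in place of a group of 11 heavy atoms (7 carbon, 2 nitrogen, 1 sulfur, 1 chlorine; one six-membered aromatic ring of carbon only), on a double-bonded ring carbon. Going by the values given here, only one measured step bears on this: a number 65 percentage points higher from compound 1 to compound 2 (beyond the scatter), which altered the same group that now leaves entirely, so a step of comparable size seems possible. The direction is uncertain; a fall is expected, since what leaves carries the variation that raised compound 2 in this assay. Compound 3 is expected to give 55%, estimated between 20% and 95%. The expected step is a number 45 percentage points lower from compound 2 to compound 3 (beyond the scatter).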

Compound 3, a percentage reported as activity, at one concentration (the size of the read-out at that concentration, not a potency): 70%
The estimate for compound 3 lay 15 percentage points below the measured number; the range from low to high includes it.
By their numbers in this assay, from the lowest: compound 1; then compound 3; then compound 2.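

In this assay the 2,5-dioxopyrrolidin-1-yl group on the double-bonded ring carbon gives a number 30 percentage points lower from compound 2 to compound 3 (beyond the scatter) but also a number 35 percentage points higher from compound 1 to compound 3 (beyond the scatter) and so places compound 3 between the two earlier compounds. A substantial read-out at this position therefore does not require the six-membered aromatic ring of compound 2 or its hydrogen-bond donors. No measurement on hand accounts for this order. Open, as far as these compounds go, is whether the two carbonyl groups of the new ring matter here, and whether a plain amine or a pyrrolidin-1-yl ring on this carbon would hold the read-out.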